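Chain extension on the triazole series: step to compound 3

This account rests on a few compounds, and the source may have more. Where it says the series, first, only, none or still open, it means among the compounds named here.

- compound 1 `CCCc1cn(C(c2ccccc2)c2ccccc2)nn1`: 11000 nM
- compound 2 `CCCCCCCc1cn(C(c2ccccc2)c2ccccc2)nn1`: 19400 nM

Both values come from an assay on isolated protein for inhibition of Aromatase (Homo sapiens), read by fluorescence and colorimetric assay, with a stated time of 30 min; a lower number here means a stronger inhibitor, a higher number a weaker inhibitor. Within the data shown here, compound 2 gives the highest of the two numbers, yet the only step that reaches it, a 1.8-fold higher number from compound 1 to compound 2 (0.25 log units; within the scatter), is within the scatter, so compound 1 and compound 2 are not distinguished by this assay.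

Compound 3 `CCCCCCCCCCc1cn(C(c2ccccc2)c2ccccc2)nn1` is not yet measured. Its change from compound 2 is propyl in place of hydrogen on a saturated chain carbon, seven bonds along the chain from an aromatic carbon. Among the measured compounds shown here, the one measured step that bears on it, a 1.8-fold higher number from compound 1 to compound 2 (0.25 log units; within the scatter), is of the same kind, a lengthening of the saturated chain, and it showed no movement beyond the scatter. A further lengthening is therefore expected to leave the number near that of compound 2, with no step beyond the scatter in either direction.

For compound 3 the estimate in this assay is 24000 nM (range 9000 nM to 65000 nM), which means an expected step of a 1.2-fold higher number from compound 2 to compound 3 (0.09 log units; within the scatter).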

Compound 3, half-maximal inhibitory concentration: 13500 nM
Beside the measured number, compound 3's estimate is 1.8-fold (0.25 log units) above it, within the range that was stated.
By their numbers in this assay, from the lowest: compounds 1, 3 and 2 (each within the scatter of the next).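

Extending the saturated chain a second time, with propyl in place of hydrogen seven bonds along the chain from an aromatic carbon, gives in this assay a 1.4-fold lower number from compound 2 to compound 3 (0.16 log units; within the scatter), and the full heptyl change gives a 1.2-fold higher number from compound 1 to compound 3 (0.09 log units; within the scatter). With both of these steps within the scatter, compound 1, compound 2 and compound 3 are not distinguished, so the three chain lengths show no trend with chain length in this assay, at either the smaller or the larger change. No measurement shown offers an explanation for this flat result.

From the compounds shown here alone, whether an amine or a carboxylic acid in place of hydrogen on the saturated chain would give a step beyond the scatter remains open. A longer chain than that of compound 3 also remains untested in the compounds shown here.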